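A few compounds are considered here, and "the series" means these few. Any claim that something is new, unique, unknown or untested is made for them only; others in the source may bear on it.

Working notes on the series. Among the compounds with values here, the three measured members share one core and differ only in the aromatic ring attached to the carbonyl carbon of the ester: compound 1 `COc1ccc(C2CC(=NOC(=O)c3ccccc3)CC(c3ccc(OC)cc3)N2C)cc1`, compound 2 `COc1ccc(C2CC(=NOC(=O)c3ccc(F)cc3)CC(c3ccc(OC)cc3)N2C)cc1` and compound 3 `COc1ccc(C2CC(=NOC(=O)c3ccc([N+](=O)[O-])cc3)CC(c3ccc(OC)cc3)N2C)cc1`. In a functional assay, with a stated time of 30 min (on this read-out lower numbers stand for stronger inhibition and higher numbers for weaker inhibition), compound 1 gives 375000 nM. In this assay compound 2 gives 152000 nM, the lowest of the three numbers. In this assay compound 3 gives 280000 nM. The steps are small: a 2.5-fold lower number from compound 1 to compound 2 (0.39 log units; beyond the scatter), a 1.3-fold lower number from compound 1 to compound 3 (0.13 log units; within the scatter) and a 1.8-fold higher number from compound 2 to compound 3 (0.27 log units; within the scatter). Compound 2 thus stands apart from compound 1 only, and cannot be separated from compound 3.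

The next member is compound 4 `COc1ccc(C2CC(=NOC(=O)c3ccccc3OC(C)=O)CC(c3ccc(OC)cc3)N2C)cc1`. Relative to compound 2 the change is 2-acetoxyphenyl in place of 4-fluorophenyl on a carbonyl carbon. Within the data shown here, no measured step covers the 2-acetoxyphenyl group. What bears on the change is the removal of fluorine, which is the reverse of a 2.5-fold lower number from compound 1 to compound 2 (0.39 log units; beyond the scatter), and the observation that neither fluoro nor nitro on the aromatic carbon moved the number far. The expected step in this assay is therefore a modest rise, a 2.0-fold higher number from compound 2 to compound 4 (0.30 log units; within the scatter), back toward the range of compound 1. For compound 4 in this assay the estimate is 300000 nM, with a range from 100000 nM to 900000 nM.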

Compound 4, half-maximal inhibitory concentration: 350000 nM
The estimate for compound 4 lay 1.2-fold (0.07 log units) below the measured number; the measured number falls inside the stated range.
By their numbers in this assay, from the lowest: compounds 2, 3, 4 and 1 (each within the scatter of the next, the first and the last beyond it).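

Adding acetoxy to the aromatic carbon of compound 1 gives no separable change in this assay (a 1.1-fold lower number from compound 1 to compound 4 (0.03 log units; within the scatter)), so the 2-acetoxyphenyl group, like the 4-nitrophenyl group of compound 3, cannot be told apart from the unsubstituted ring. Replacing 4-fluorophenyl on the carbonyl carbon does register (a 2.3-fold higher number from compound 2 to compound 4 (0.36 log units; beyond the scatter)), whereas the comparison with the 4-nitrophenyl ester stays unresolved (a 1.3-fold higher number from compound 3 to compound 4 (0.10 log units; within the scatter)). Compound 2 now stands apart from both compound 1 and compound 4 but still not from compound 3, so the 4-fluorophenyl group is the only ring in the series with any separable step, and nothing available accounts for this.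

Open, on these data alone, is whether a hydroxyl, an amine or a carboxylic acid on this ring would move the number further than fluoro, nitro or acetoxy do, given that all four compounds remain close together. Also open, as far as these compounds go, is whether the result for compound 4 belongs to the acetoxy group or to its place, since fluoro and nitro appear here only in 4-substituted rings and acetoxy only in a 2-substituted ring.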